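This account rests on a few compounds, and the source may have more. Where it says the series, first, only, none or still open, it means among the compounds named here.

Compound 1 `COC(=O)c1sc2cc(Nc3ccccc3Br)cnc2c1N` is the anchor of this short series. In a functional assay on NCI-H460 cells (Homo sapiens) for inhibition, read by sulforhodamine B assay, with a stated time of 48 h (a lower number here means a stronger inhibitor of growth, a higher number a weaker inhibitor of growth), compound 1 gives 30900 nM, which places it second highest of the three numbers recorded so far. Compound 2 `COC(=O)c1sc2cc(Nc3ccc(F)cc3Br)cnc2c1N` adds a fluoro to the aromatic ring and gives 31300 nM; the step of a 1.0-fold higher number from compound 1 to compound 2 (0.01 log units; within the scatter) is within the scatter. Within the data shown here, compound 3 `COC(=O)c1sc2cc(Nc3nc4ccccc4s3)cnc2c1N` carries a bicyclic heteroaryl on the same nitrogen and gives 6400 nM, a lower number than compound 1 by a gap that lies beyond the scatter, though no single-point step connects the two.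

Compound 4 `COC(=O)c1sc2cc(Nc3ccccn3)cnc2c1N` is the next member. Its difference from compound 1 is pyridin-2-yl in place of 2-bromophenyl on a nitrogen on an aromatic ring. Among the measured compounds shown here, only one measured step, from compound 1 to compound 2, touches the group on that nitrogen, and it left the number unchanged; it does not replace the ring itself, so it offers little guidance. For the measured compounds named here, the values of compound 1 and compound 3 show that a heteroaryl on that nitrogen can go with a lower number, but no measured step isolates that exchange. Compound 4 is therefore expected to give a number that is modestly lower than compound 1, with wide uncertainty, the expected step being a 2.1-fold lower number from compound 1 to compound 4 (0.31 log units; beyond the scatter). The estimate for compound 4 in this assay is 15000 nM, within a range from 5000 nM to 45000 nM.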

Compound 4, concentration for 50% growth inhibition: > 150000 nM
Compound 4 gave a limit, no number; the forecaster's own chance of this, stated with the estimate: 10%; at least 10-fold (1.00 log units) between middle value and limit.
By their numbers in this assay, from the lowest: compound 3; then compounds 1 and 2 (each within the scatter of the next). At a limit, above all of these: compound 4.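

Among these compounds, the exchange of 2-bromophenyl for pyridin-2-yl on a nitrogen on an aromatic ring is the first single change to lie beyond the scatter, the step in this assay being an at least 4.8-fold higher number from compound 1 to compound 4 (0.68 log units; beyond the scatter). Compound 4 gives a limit and no number: the limit of > 150000 nM in this assay, at which 1 of the 4 values shown sits. Among the compounds shown here, the only earlier step, a 1.0-fold higher number from compound 1 to compound 2 (0.01 log units; within the scatter), kept the ring on that nitrogen and lay within the scatter, whereas this step replaces the ring itself, and it shows that a heteroaryl ring in this place does not by itself go with a lower number, as the value of compound 3 alone might have suggested.

The loss of the bromine and the entry of the ring nitrogen arrive together in this one step, so the compounds shown cannot say which of the two goes with the change, or how large the change really is. A plain phenyl on that nitrogen would separate the two, and a pyridin-3-yl would show whether the place of the ring nitrogen matters.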